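Carbamate to Amide Change and Cytotoxicity in Vero Cells

The source may report more compounds than this note shows. Statements on the series, on what has been measured and on what is new or still open speak of the compounds shown alone.

Of the compounds shown here, three that share one core have been tested in an ADME assay on Vero cells (Chlorocebus sabaeus) for cytotoxicity, read by resazurin assay, with a stated time of 3 days; on this read-out lower numbers stand for stronger inhibition and higher numbers for weaker inhibition. Compound 1 `CCN(CC)c1cc2[nH]c(C3CCCCC3)nc2cc1NC(=O)OCCOCCOC` gives > 100 ug/mL, which is a limit of the assay rather than a number. Compound 2 `CCCCOC(=O)Nc1cc2nc(C3CCCCC3)[nH]c2cc1N(CC)CCN(C)C` likewise gives > 100 ug/mL, again a limit. Compound 3 `CN(C)c1cc2[nH]c(C3CCCCC3)nc2cc1NC(=O)OCc1ccccc1` gives > 100 ug/mL, also a limit. Because (the limit of > 100 ug/mL in this assay, at which 3 of the 3 values shown sit), compound 3 stands exactly where its two companions stand, and nothing separates the three compounds on this read-out. Compound 4 `CN(C)c1cc2[nH]c(C3CCCCC3)nc2cc1NC(=O)c1ccc(C(C)(C)C)cc1` differs from compound 3 in one place: 4-(tert-butyl)phenyl in place of benzyloxy on a carbonyl carbon. For the measured compounds named here, no step between measured compounds is available to size this change, and a limit on compound 3 leaves the true size open. The author expects compound 4 to stay with the others, with a step of a number no higher from compound 3 to compound 4 (the limit leaves the size open) in this assay of none beyond the scatter. The estimate for compound 4 in this assay is 100 ug/mL, with a range from 40 ug/mL to 250 ug/mL, and a fair chance that only a limit is again reported.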

Compound 4, half-maximal inhibitory concentration: > 100 ug/mL
Compound 4 was reported as a limit; the forecaster's own chance of this, stated with the estimate: 65%; the middle value sits exactly at the limit.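

No step from compound 3 to compound 4 can be read in this assay, since both values are limits: the limit of > 100 ug/mL in this assay, at which 4 of the 4 values shown sit.

The compounds shown leave open where any of them would give an actual number, and so whether 4-(tert-butyl)phenyl in place of benzyloxy changes this read-out at all.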